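Moving the hydroxyl group of compound 1

The source may hold more compounds than are shown below. What is called first, only, known or untested is meant among the compounds shown, and "the series" means these compounds.

In a functional assay on HL-60 cells (Homo sapiens) for cytotoxicity, read by ELISA, with a stated time of 2 days (a higher number here means a weaker inhibitor, a lower number a stronger inhibitor), compound 1 (`Oc1cccc(-c2cc(-c3ccccc3)cc(-c3ccccc3)n2)c1`) gives 11500 nM and compound 2 (`Oc1cccc(-c2cc(-c3ccccc3)cc(-c3ccco3)n2)c1`) gives 9910 nM. These two numbers, the only ones available, lie within the scatter of each other, so compound 1 stands level with compound 2.

Compound 3 (`Oc1ccc(-c2cc(-c3ccccc3)cc(-c3ccccc3)n2)cc1`) keeps the core of compound 1 and differs in one group, with 4-hydroxyphenyl in place of 3-hydroxyphenyl on an aromatic carbon. Among the compounds with values here, the only measured step, a 1.2-fold lower number from compound 1 to compound 2 (0.06 log units; within the scatter), is a different change, furan-2-yl in place of phenyl, and it leaves the 3-hydroxyphenyl group untouched. It stays within the scatter, but it bears only indirectly on this question. Within the data shown here, no measurement yet shows what the new hydroxyl position does, so no clear direction is expected in this assay, and no step beyond the scatter. The expected step is a 1.2-fold lower number from compound 1 to compound 3 (0.06 log units; within the scatter). For compound 3 the estimate is 10000 nM, with an expected range from 3500 nM to 30000 nM.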

Compound 3, half-maximal inhibitory concentration: 1400 nM
For compound 3 the middle estimate is 7.1-fold (0.85 log units) above the measured one; the measured number lies below the stated range.
By their numbers in this assay, from the lowest: compound 3; then compounds 2 and 1 (each within the scatter of the next).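

In this assay, the step of an 8.2-fold lower number from compound 1 to compound 3 (0.91 log units; beyond the scatter) comes from 4-hydroxyphenyl in place of 3-hydroxyphenyl alone, so the group next to the ring nitrogen responds to where its hydroxyl sits, although the two groups have the same counts of heavy atoms, donors and acceptors. Within the data shown here, the earlier step of a 1.2-fold lower number from compound 1 to compound 2 (0.06 log units; within the scatter), a change of a different group, stayed within the scatter, and this is the first step to go beyond it. No evidence is at hand that accounts for the difference between the two hydroxyl positions.

From the compounds shown here alone, whether the same change holds with furan-2-yl in place of a phenyl group remains open. Going by these compounds, it is also open whether the hydroxyl itself is needed on the 4-hydroxyphenyl group, or whether a methoxy group or an amine in its place would serve as well.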